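The source may report more compounds than this note shows. Statements on the series, on what has been measured and on what is new or still open speak of the compounds shown alone.

For the measured compounds named here, the two compounds measured so far share one core and differ in how the amine is substituted and where the diphenylamine ether sits. In a functional assay on HCT-116 cells (Homo sapiens) for inhibition, read by MTT assay, with a stated time of 72 h (on this read-out lower numbers stand for stronger inhibition and higher numbers for weaker inhibition), compound 1 `COc1ccc(CCCNCc2c(OC)cc(Oc3ccc(Nc4ccccc4)cc3)cc2OC)cc1` gives 3230 nM. Compound 2 `CNCc1c(OC)cc(Oc2cccc(Nc3ccccc3)c2)cc1OC` is reported only as > 20000 nM in this assay, which is a limit and not a number. Going by the values given here, that puts compound 2 at the limit of > 20000 nM in this assay, at which 1 of the 2 values shown sits, so the gap between compound 1 and compound 2 can be given no exact size; the numbers say only that compound 1 gives a measured value while compound 2 does not.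

Compound 3 `COc1cc(Oc2cccc(Nc3ccccc3)c2)cc(OC)c1CNCc1ccc(Cl)cc1` has not yet been measured. Compared with compound 2 it carries 4-chlorophenyl in place of hydrogen on a saturated chain carbon bound to an amine nitrogen. Among the compounds with values here, no measured pair isolates this change, so its effect can only be guessed. Because compound 1 gives 3230 nM, a measurable value is at least within reach for this core. The step from compound 2 to compound 3 is expected to be an at least 2.0-fold lower number from compound 2 to compound 3 (0.30 log units; that floor lies within the scatter), toward stronger inhibition. For compound 3 the estimate in this assay is 10000 nM, with a range from 3000 nM to 40000 nM.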

Compound 3, half-maximal inhibitory concentration: 3310 nM
The estimate for compound 3 lay 3.0-fold (0.48 log units) above the measured number; the range from low to high includes it.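

This result shows that the position carrying the methyl in compound 2 tolerates a much larger group in this series. Going from methyl to 4-chlorobenzyl gives an at least 6.0-fold lower number from compound 2 to compound 3 (0.78 log units; beyond the scatter) in this assay, the first single change shown here to lead from a limit to a measured number. The value for compound 2 is a limit and not a number, so this step has a floor but no exact size, and the true gain could be larger: the limit of > 20000 nM in this assay, at which 1 of the 3 values shown sits.

This one pair cannot separate the contribution of the added aromatic ring from that of its chlorine, nor show whether size alone matters, and an unsubstituted benzyl group or a small chain such as ethyl at the same place would begin to answer that. It also leaves open how far the trend extends to other replacements, such as a 4-fluorobenzyl or 4-methoxybenzyl group, and whether any of them would carry this core to clearly lower numbers.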